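A few compounds are considered here, and "the series" means these few. Any claim that something is new, unique, unknown or untested is made for them only; others in the source may bear on it.

Measured so far:
compound 1, `O=C(COc1ccc(C(=O)/C=C/c2ccc(F)cc2)cc1)N[C@H]1CCOC1=O`, 15600 nM
compound 2, `CC(C)c1ccc(NCC(=O)N[C@H]2CCOC2=O)cc1`, > 64000 nM (a limit)
compound 3, `O=C(CNc1ccc(Cl)cc1Cl)N[C@H]1CCOC1=O`, > 64000 nM (a limit)

All three come from a functional assay on PC-3 cells (Homo sapiens) for antiproliferative activity, read by MTT assay, with a stated time of 72 h; on this read-out higher numbers stand for weaker inhibition and lower numbers for stronger inhibition. For the measured compounds named here, compound 1 holds the only number in the set. For compound 2 the value is a limit of this assay. For compound 3 the value is likewise a limit (the limit of > 64000 nM in this assay, at which 2 of the 3 values shown sit).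

Compound 4, `O=C(COc1ccc(C(=O)/C=C/c2ccccc2Br)cc1)N[C@H]1CCOC1=O`, differs from compound 1 in one place: 2-bromophenyl in place of 4-fluorophenyl on a double-bonded chain carbon bound to a double-bonded chain carbon. Going by the values given here, no measured pair shows a change of this kind, so no step size can be read from the data. The expectation is a step from compound 1 to compound 4 of a 1.2-fold lower number from compound 1 to compound 4 (0.08 log units; within the scatter), none beyond the usual scatter. Compound 4 is thus estimated at 13000 nM, within 4500 nM to 40000 nM.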

Compound 4, half-maximal inhibitory concentration: 3260 nM
Compound 4: the middle estimate sits 4.0-fold (0.60 log units) above what was measured, outside the stated range (below it).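

In this assay, the aryl group on a double-bonded chain carbon bound to a double-bonded chain carbon proves to be a place where the read-out responds: 2-bromophenyl in place of 4-fluorophenyl gives a 4.8-fold lower number from compound 1 to compound 4 (0.68 log units; beyond the scatter). The rest of the core of compound 1 stays unchanged in this step, so the whole shift belongs to this one exchange. Nothing shown gives a cause for it.

The exchange alters the halogen and its ring position together, and the two cannot be separated here. On these data alone, how 4-bromophenyl or 2-fluorophenyl would read at this place stays open.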